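A few compounds are considered here, and "the series" means these few. Any claim that something is new, unique, unknown or untested is made for them only; others in the source may bear on it.

Of the compounds shown here, three built on one shared core have been tested in a functional assay on A549 cells (Homo sapiens) for inhibition, read by MTT assay, with a stated time of 48 h; a lower number here means a stronger inhibitor, a higher number a weaker inhibitor. Compound 1 `COc1ccc2c(=O)c(/C=C/C(=O)Nc3ccc(Cl)cc3)coc2c1` gives only a limit of the assay, > 100000 nM. Compound 2 `CCOc1ccc(NC(=O)/C=C/c2coc3cc(OC)ccc3c2=O)cc1` likewise gives only a limit, > 100000 nM. Compound 3 `COc1ccc2c(=O)c(/C=C/C(=O)NCc3ccc(C)cc3)coc2c1` also gives only a limit, > 100000 nM. Because (the limit of > 100000 nM in this assay, at which 3 of the 3 values shown sit), none of the three can be placed relative to the others: the step that the two limits leave unreadable from compound 1 to compound 2, the step that the two limits leave unreadable from compound 1 to compound 3 and the step that the two limits leave unreadable from compound 2 to compound 3 are all unreadable, so compound 3 stands simply at the limit alongside the other two.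

Compound 4 `COc1ccc2c(=O)c(/C=C/C(=O)Nc3ccccc3OC)coc2c1` has not yet been measured. It differs from compound 3 in one place: 2-methoxyphenyl in place of 4-methylbenzyl on an amide-type nitrogen. Every measured step in this series is hidden by the limit, so none of them gives a readable size for a change on the amide nitrogen, and nothing here points in either direction.

On that basis compound 4 is expected to remain at the limit, with an estimated value of 100000 nM, somewhere between 30000 nM and 300000 nM. The step of a number no higher from compound 3 to compound 4 (the limit leaves the size open) is therefore expected to be essentially none.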

Compound 4, half-maximal inhibitory concentration: > 100000 nM
Compound 4: no number, only a limit; the forecaster's own chance of this, stated with the estimate: 80%; the middle value lies on the limit itself.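

In this assay compound 4 gives only a limit, > 100000 nM. Its steps from compound 1, compound 2 and compound 3 therefore cannot be read: the limit of > 100000 nM in this assay, at which 4 of the 4 values shown sit. The compounds shown leave open how strongly any of the four inhibits, and whether changing the group on the amide-type nitrogen makes any difference.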